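Oxane Amide in Place of Furan on a Shared Core

A few compounds are considered here, and "the series" means these few. Any claim that something is new, unique, unknown or untested is made for them only; others in the source may bear on it.

Compound 1 `COc1ccc(-c2cnc(NC(=O)c3ccco3)n2C)cc1` is one of three compounds examined in a toxicity assay on THP-1 cells (Homo sapiens) for inhibition; on this read-out lower numbers stand for higher toxicity in this test and higher numbers for lower toxicity in this test. Compound 1 gives > 100000 nM, which is a limit of the assay and not a number. Compound 1 therefore stands at the limit of > 100000 nM in this assay, at which 2 of the 3 values shown sit. Compound 3 `COc1cccc(-c2cnc(NC(=O)c3ncc[nH]3)n2C)c1` likewise gives > 100000 nM, also a limit. Compound 2 `Cn1c(-c2ccc(Cl)cc2)cnc1NC(=O)c1ncc[nH]1` gives 52000 nM. Compound 4 `COc1ccc(-c2cnc(NC(=O)C3CCOCC3)n2C)cc1` has not yet been measured in this assay; it differs from compound 1 by oxan-4-yl in place of furan-2-yl on a carbonyl carbon. Within the data shown here, no measured pair differs in one place, so no step size is known from the data. With compound 1 at a limit, the step of a number no higher from compound 1 to compound 4 (the limit leaves the size open) is expected to stay within the scatter, with no change in either direction. Compound 4 is estimated at 100000 nM, with a range from 50000 nM to 300000 nM.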

Compound 4, half-maximal cytotoxic concentration: > 100000 nM
Compound 4 was reported as a limit; the forecaster's own chance of this, stated with the estimate: 70%; the middle value sits exactly at the limit.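

Compound 1 and compound 4 both stand at a limit of this assay, not at a number, so no step between them can be read: the limit of > 100000 nM in this assay, at which 3 of the 4 values shown sit.

The compounds shown leave open whether oxan-4-yl in place of furan-2-yl on a carbonyl carbon changes this read-out at all.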